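A few compounds are considered here, and "the series" means these few. Any claim that something is new, unique, unknown or untested is made for them only; others in the source may bear on it.

Compound 1 `O=C(NCc1ccccc1)c1cn(-c2ccccc2)nc1-c1cccnc1` gave no usable number in a functional assay on Raji cells (Homo sapiens) for cytotoxicity, read by MTT assay, with a stated time of 48 h; on this read-out higher numbers stand for weaker inhibition and lower numbers for stronger inhibition; for compound 1 the entry reads "nd(insoluble)" (no result reported). Compound 2 `O=C(NCc1ccccc1)c1cn(-c2ccccc2)nc1-c1ccncc1` reached only a limit of the assay in this assay, namely > 100000 nM, which is the point noted as the limit of > 100000 nM in this assay, at which 1 of the 2 values shown sits. Compound 3 `O=C(O)c1cn(-c2ccccc2)nc1-c1ccncc1` carries hydroxy in place of benzylamino on a carbonyl carbon. Within the data shown here, no measured step connects these two, and since compound 2 stands at the limit, the step from compound 2 to compound 3 is expected to be none beyond the scatter, a step that the limit leaves unreadable from compound 2 to compound 3. Compound 3 is estimated at 150000 nM, in a range from 50000 nM to 500000 nM, most probably reported again only as a limit.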

Compound 3, half-maximal inhibitory concentration: > 100000 nM
Compound 3: a limit, no number (the forecaster's own chance of this, stated with the estimate: 85%); the middle value lies beyond the limit too.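

Compound 2 and compound 3 both end at a limit of the assay, so no step can be read between them: the limit of > 100000 nM in this assay, at which 2 of the 3 values shown sit. The compounds shown leave open whether any of them has an effect in this assay that can be given as a number.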